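Lengthening the amine side chain: compound 2 to compound 3

A few compounds are considered here, and "the series" means these few. Any claim that something is new, unique, unknown or untested is made for them only; others in the source may bear on it.

Measured in a toxicity assay on L6 cells (Rattus norvegicus) for inhibition, read by microscopy and resazurin assay, with a stated time of 70 h; on this read-out lower numbers stand for stronger inhibition and higher numbers for weaker inhibition:
- compound 1 `CC1(C)C=Cc2cc(CNCc3ccccc3)c(O)cc2O1`: 57000 nM
- compound 2 `CC1(C)C=Cc2cc(CNCCCc3ccccc3)c(O)cc2O1`: 28000 nM

Among the compounds with values here, compound 2 holds the lower of the two numbers so far, and compound 1 is its only neighbour. The next analogue, compound 3 `CC1(C)C=Cc2cc(CNCCCCc3ccccc3)c(O)cc2O1`, is not yet measured. It differs from compound 2 as follows: benzyl in place of phenyl on a saturated chain carbon, three bonds along the chain from an amine nitrogen. In words, this is benzyl in place of phenyl on a saturated chain carbon, three bonds along the chain from an amine nitrogen.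

Within the data shown here, only one measured step bears on this change: a 2.0-fold lower number from compound 1 to compound 2 (0.31 log units; beyond the scatter). That step is modest, though beyond the scatter, and it is a single observation. A similar or smaller move towards a lower number is therefore expected, and a step within the scatter remains possible. The estimated change in this assay is a 1.4-fold lower number from compound 2 to compound 3 (0.15 log units; within the scatter). Compound 3 is expected at 20000 nM, with an estimated range of 10000 nM to 40000 nM.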

Compound 3, half-maximal inhibitory concentration: 19000 nM
Compound 3: middle estimate off by 1.1-fold (0.02 log units), on the high side; measured number inside the range.
By their numbers in this assay, from the lowest: compounds 3 and 2 (each within the scatter of the next); then compound 1.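

In this assay, benzyl in place of phenyl on a saturated chain carbon, three bonds along the chain from an amine nitrogen, gives a 1.5-fold lower number from compound 2 to compound 3 (0.17 log units; within the scatter). Set against a 2.0-fold lower number from compound 1 to compound 2 (0.31 log units; beyond the scatter), which lies beyond the scatter, this second change at the same position does not separate its two compounds, so the earlier step does not extend into a measurable series of steps. No measurement at hand bears on the size of either step.

Open, as far as these compounds go, is whether a longer chain than that of compound 3 would give a number outside the scatter of compound 3. Also open, from the compounds shown here alone, is how a carboxylic acid or an amine in place of the phenyl would read in this assay.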